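The source may report more compounds than this note shows. Statements on the series, on what has been measured and on what is new or still open speak of the compounds shown alone.

Measured in a functional assay on MCF7 cells (Homo sapiens) for inhibition, read by MTT assay, with a stated time of 48 h; on this read-out lower numbers stand for stronger inhibition and higher numbers for weaker inhibition:
Compound 1 `COc1ccc(OC)c(C(c2c[nH]c3ccc(Br)cc23)c2c[nH]c3ccc(Br)cc23)c1`: 2800 nM
Compound 2 `Brc1ccc2[nH]cc(C(c3c[nH]c4ccc(Br)cc34)C3CCCCC3)c2c1`: 4100 nM

Only these two compounds have been measured, and compound 2 stands within the scatter of compound 1, so the pair cannot be told apart. Compound 3 `CCCC(c1c[nH]c2ccc(Br)cc12)c1c[nH]c2ccc(Br)cc12` is still to be measured. It has propyl in place of cyclohexyl on a saturated chain carbon bound to two aromatic carbons. Among the measured compounds shown here, one measured step bears on this change, a replacement at the same place, and it gives a 1.5-fold higher number from compound 1 to compound 2 (0.17 log units; within the scatter). For the measured compounds named here, this single step offers thin evidence, and no measurement yet shows what propyl does there. With nothing measured beyond the scatter, no clear direction is expected. The expected result is a 1.0-fold lower number from compound 2 to compound 3 (0.01 log units; within the scatter). For compound 3 the estimated value is 4000 nM, with an expected range of 1500 nM to 11000 nM.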

Compound 3, half-maximal inhibitory concentration: 3600 nM
Beside the measured number, compound 3's estimate is 1.1-fold (0.05 log units) above it; low and high end bracket the measured number.
By their numbers in this assay, from the lowest: compounds 1, 3 and 2 (each within the scatter of the next).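

Replacing cyclohexyl with propyl on the saturated chain carbon bound to two aromatic carbons gives a 1.1-fold lower number from compound 2 to compound 3 (0.06 log units; within the scatter) in this assay and so leaves the number within the scatter although the ring is gone. Set against 2,5-dimethoxyphenyl, propyl gives a 1.3-fold higher number from compound 1 to compound 3 (0.11 log units; within the scatter) and so adds an open chain to the two ring groups already seen at this place, with none of the three told apart from another on this read-out. No measured evidence accounts for this insensitivity.

The compounds shown leave open whether any group at this place can move the number beyond the scatter, and an amine, a carboxylic acid or a longer chain would each test that. They also leave open what a change to the shared core would do.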